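The source may report more compounds than this note shows. Statements on the series, on what has been measured and on what is new or still open speak of the compounds shown alone.

Working notes on the series.

Compound 1 `CN1CCN(c2nc3c(cc2[N+](=O)[O-])c(=O)c(C(=O)O)cn3C2CC2)CC1c1ccccc1` and compound 3 `CN1CCN(c2nc3c(cc2[N+](=O)[O-])c(=O)c(C(=O)O)cn3-c2ccc(F)cc2)CC1c1ccccc1` are built on one core; compound 2 `CC1CN(c2nc3c(cc2[N+](=O)[O-])c(=O)c(C(=O)O)cn3C2CC2)CC(C)O1` and the unmeasured compound 4 `CC1CN(c2nc3c(cc2[N+](=O)[O-])c(=O)c(C(=O)O)cn3-c2ccc(F)cc2)CC(C)O1` are built on another. The difference between the two cores is not broken down here.

In an ADME assay on Vero cells (Chlorocebus sabaeus) for cytotoxicity, read by MTT assay, with a stated time of 72 h (a lower number here means a stronger inhibitor, a higher number a weaker inhibitor), compound 1 gives 139000 nM. In this assay compound 3 gives 124000 nM. The change between them is 4-fluorophenyl in place of cyclopropyl on an aromatic nitrogen and the step it made is a 1.1-fold lower number from compound 1 to compound 3 (0.05 log units; within the scatter), so the two values are not told apart.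

For compound 2 this assay yields only a limit, > 160000 nM, as the limit of > 160000 nM in this assay, at which 1 of the 3 values shown sits, records.

The change from compound 2 to compound 4 is 4-fluorophenyl in place of cyclopropyl on an aromatic nitrogen, the same change as from compound 1 to compound 3, at the same place. Resting on compound 1 to compound 3 with a 1.1-fold lower number from compound 1 to compound 3 (0.05 log units; within the scatter), the expected step from compound 2 to compound 4 in this assay is a step that the limit leaves unreadable from compound 2 to compound 4, and compound 4 is expected to sit at or near the limit, so a number may again not be returned. The estimate for compound 4 in this assay is 170000 nM, expected between 100000 nM and 300000 nM.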

Compound 4, half-maximal inhibitory concentration: 141000 nM
Compound 4: the middle estimate sits 1.2-fold (0.08 log units) above what was measured, and the stated range covers the measured number.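

Carried to the core of compound 2, 4-fluorophenyl in place of cyclopropyl on the aromatic nitrogen gives an at least 1.1-fold lower number from compound 2 to compound 4 (0.05 log units; that floor lies within the scatter) in this assay. Compound 2 has only a limit of the assay, > 160000 nM, so this step is a floor and not a measured size. Neither core shows a step printed as beyond the scatter, but the pair of steps does not establish that the change carries over with the same size, nor that its size differs between the cores: the same change on two cores in this assay, a 1.1-fold lower number (0.05 log units; within the scatter) from compound 1 to compound 3 and an at least 1.1-fold lower number (0.05 log units; that floor lies within the scatter) from compound 2 to compound 4; the limit leaves it open whether they differ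

The compounds shown leave open the actual size of the step on the core of compound 2, which would take a number in place of the limit. Also open, as far as these compounds go, is how this assay reads other groups on the aromatic nitrogen, such as an ethyl or an unsubstituted phenyl, and an amine in place of the nitro group on either core.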